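The source may report more compounds than this note shows. Statements on the series, on what has been measured and on what is new or still open speak of the compounds shown alone.

Measured in a functional assay on SK-MEL-28 cells (Homo sapiens) for cytotoxicity, read by MTT assay, with a stated time of 3 days; on this read-out higher numbers stand for weaker inhibition and lower numbers for stronger inhibition:

Compound 1 `N#Cc1c(O)nc(SCc2nc3ccccc3[nH]2)nc1-c1ccccc1` gives 7.7 nM
Compound 2 `CNc1nc(SCc2nc3ccccc3[nH]2)nc(-c2ccccc2)c1C#N` gives 2.87 nM
Compound 3 `N#Cc1c(NC(N)=S)nc(SCc2nc3ccccc3[nH]2)nc1-c1ccccc1` gives 4.8 nM

On these numbers, compound 3 lies between the other two and within the scatter of both. Only compound 1 and compound 2 are separated beyond the scatter. Compound 4 `N#Cc1c(-c2ccccc2)nc(SCc2nc3ccccc3[nH]2)nc1N1CCNCC1` carries piperazin-1-yl on an aromatic carbon ortho to a cyano group, and the change from compound 3 is a group of 6 heavy atoms (4 carbon, 2 nitrogen; one six-membered non-aromatic ring with 2 hetero atoms) in place of a group of 4 heavy atoms (1 carbon, 2 nitrogen, 1 sulfur; no ring), on an aromatic carbon.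

The three measured compounds differ only in the group on this same carbon, so their steps are the relevant guide. The largest, and the only one beyond the scatter, is the modest 2.7-fold lower number from compound 1 to compound 2 (0.43 log units; beyond the scatter). The others, a 1.6-fold lower number from compound 1 to compound 3 (0.21 log units; within the scatter) and a 1.7-fold higher number from compound 2 to compound 3 (0.22 log units; within the scatter), stay within the scatter. None of the three compounds has a ring at this place, so the data do not directly test the entering piperazin-1-yl. With that caveat, the small size of these steps leads to the expectation of no change beyond the scatter in this assay, though the uncertainty is wider than for a measured step. The expected result is a 1.1-fold lower number from compound 3 to compound 4 (0.03 log units; within the scatter). For compound 4 the estimated value is 4.5 nM, with an expected range from 1.5 nM to 14 nM.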

Compound 4, half-maximal inhibitory concentration: 2.6 nM
Beside the measured number, compound 4's estimate is 1.7-fold (0.24 log units) above it; the measured number falls inside the stated range.
By their numbers in this assay, from the lowest: compounds 4, 2, 3 and 1 (each within the scatter of the next, the first and the last beyond it).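

In this assay, a ring on this aromatic carbon, ortho to a cyano group, is accommodated: with piperazin-1-yl entering, a 1.8-fold lower number from compound 3 to compound 4 (0.27 log units; within the scatter) and a 1.1-fold lower number from compound 2 to compound 4 (0.04 log units; within the scatter) both stay within the scatter, so the ring sits level with the open-chain groups of compound 2 and compound 3. The comparison with the hydroxy compound is the only one that separates, with a 3.0-fold lower number from compound 1 to compound 4 (0.47 log units; beyond the scatter) beyond the scatter, and it matches the methylamino result, a 2.7-fold lower number from compound 1 to compound 2 (0.43 log units; beyond the scatter), so compound 2 and compound 4 stand apart from compound 1 by a similar margin. Compound 3 goes against any general rule for groups attached through nitrogen, as a 1.6-fold lower number from compound 1 to compound 3 (0.21 log units; within the scatter) stays within the scatter.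

The compounds shown leave open whether the second nitrogen of the piperazin-1-yl ring counts for anything, which a morpholine or piperidine ring on the same carbon would test. They also leave open how far this carbon accepts other kinds of group, such as a carboxylic acid or a longer amine chain. Nothing available here bears on the reason for these results.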